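Shortening a side chain on a second core

The source may report more compounds than this note shows. Statements on the series, on what has been measured and on what is new or still open speak of the compounds shown alone.

Compound 1 `CC/C=C\C/C=C\C/C=C\CCCCCCCC1(O)CC(=O)c2c(O)cc(OCOC)cc2O1` and compound 2 `CCCC/C=C\CCCCCCCCCC1(O)CC(=O)c2c(O)cc(OCOC)cc2O1` share one core. In a functional assay on MDA-MB-231 cells (Homo sapiens) for antiproliferative activity, read by MTT assay (on this read-out lower numbers stand for stronger inhibition and higher numbers for weaker inhibition), compound 1 gives 6790 nM, while compound 2 gives 42800 nM. The change between them is a group of 8 heavy atoms (8 carbon; no ring) in place of a group of 10 heavy atoms (10 carbon; no ring), on a saturated chain carbon, seven bonds along the chain from a saturated ring carbon, and its step was a 6.3-fold higher number from compound 1 to compound 2 (0.80 log units; beyond the scatter). Compound 3 `CC/C=C\C/C=C\C/C=C\CCCCCCCc1cc(=O)c2c(O)c(C)c(O)c(C)c2o1` carries a different core; the difference between the two cores is not broken down here. In this assay compound 3 gives 6790 nM. Compound 4 `CCCC/C=C\CCCCCCCCCc1cc(=O)c2c(O)c(C)c(O)c(C)c2o1` is made from compound 3 by the same kind of change, (a group of 8 heavy atoms (8 carbon; no ring) in place of a group of 10 heavy atoms (10 carbon; no ring), on a saturated chain carbon, seven bonds along the chain from an aromatic carbon), here seven bonds from an aromatic carbon rather than from a saturated ring carbon. Because the step of a 6.3-fold higher number from compound 1 to compound 2 (0.80 log units; beyond the scatter) was modest but clear, compound 4 is expected to show a similar weakening, a 5.9-fold higher number from compound 3 to compound 4 (0.77 log units; beyond the scatter). The estimate for compound 4 in this assay is 40000 nM, between 15000 nM and 110000 nM.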

Compound 4, half-maximal inhibitory concentration: > 87000 nM
Compound 4 gave a limit, no number (the forecaster's own chance of this, stated with the estimate: 10%); middle value at least 2.1-fold (0.33 log units) away from the limit.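

In this assay compound 4 gives only a limit of the assay, not a number: > 87000 nM. Putting the oct-3-en-1-yl chain in place of the longer chain of compound 3 weakens inhibition on this second core too, an at least 12-fold higher number from compound 3 to compound 4 (1.10 log units; beyond the scatter). The direction of the change therefore carries over between these two cores, but whether its size does remains unsettled: the same change on two cores in this assay, a 6.3-fold higher number (0.80 log units; beyond the scatter) from compound 1 to compound 2 and an at least 12-fold higher number (1.10 log units; beyond the scatter) from compound 3 to compound 4; the limit leaves it open whether they differ

The two chains differ in both length and number of double bonds, and the compounds shown do not separate these two features. A fully saturated chain or a longer chain on either core could help tell them apart.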